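This account rests on a few compounds, and the source may have more. Where it says the series, first, only, none or still open, it means among the compounds named here.

Among the compounds with values here, in a functional assay on KB cells (Homo sapiens) for cytotoxicity (a lower number here means a stronger inhibitor, a higher number a weaker inhibitor), three compounds have numbers so far. Compound 1 `CCCCOC1=CC(=O)c2ccccc2C1=O` gives 27000 nM, compound 2 `O=C1C=CC(=O)c2cc(OCc3ccccc3)ccc21` gives 26200 nM, and compound 3 `CCOc1ccc2c(c1)C(=O)C=CC2=O` gives 21400 nM. Compound 3 therefore stands level with the other two, as its gaps to both lie within the scatter of repeated measurements.

The next compound, compound 4 `O=C1C=CC(=O)c2cc(Oc3cccs3)ccc21`, keeps the core of compound 3 and changes one group: thiophen-2-yl in place of ethyl on an oxygen on an aromatic ring. In short, thiophen-2-yl takes the place of ethyl on an oxygen on an aromatic ring.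

Within the data shown here, only one measured step bears on this change. It is a 1.2-fold lower number from compound 2 to compound 3 (0.09 log units; within the scatter), where methyl replaces phenyl on a saturated chain carbon bound to an oxygen on an aromatic ring. That swap left the number within the scatter, so it offers no reason to expect a large move. Among the measured compounds shown here, it is only a loose guide, though, since no measured compound carries thiophen-2-yl.

The estimated change is a 1.2-fold lower number from compound 3 to compound 4 (0.08 log units; within the scatter), so no shift beyond the scatter is expected. For compound 4 the estimate is 18000 nM, with an expected range of 6000 nM to 40000 nM.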

Compound 4, half-maximal inhibitory concentration: 18300 nM
Compound 4: the middle estimate sits 1.0-fold (0.01 log units) below what was measured, within the range that was stated.
By their numbers in this assay, from the lowest: compounds 4, 3, 2 and 1 (each within the scatter of the next).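

Up to this point, the oxygen on the aromatic ring had carried only groups joined through a saturated chain carbon. Compound 4 puts thiophen-2-yl, a five-membered aromatic ring with 1 hetero atom, on that oxygen in place of ethyl, and in this assay the result is a 1.2-fold lower number from compound 3 to compound 4 (0.07 log units; within the scatter), so this larger ring-bearing group leaves the number level with that of the ethyl compound. No measurement is available that would explain this result.

Still open, from the compounds shown here alone, is whether any group on this oxygen can move the number beyond the scatter, for example a longer chain such as hexyl, or a chain ending in an amine or a carboxylic acid. A phenyl group on the same oxygen would also be needed to show whether the sulfur of thiophen-2-yl matters at all.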